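Mono-fluoro ring at the benzylidene arm of compound 3

This account rests on a few compounds, and the source may have more. Where it says the series, first, only, none or still open, it means among the compounds named here.

The series shares one core carrying two ring-bearing double-bonded arms. Compound 1 `Cc1cccc(/C=C2\CCC/C(=C\c3ccccc3)C2=O)c1` gives 47.9% in an assay on isolated protein for inhibition of Alpha glucosidase (Homo sapiens), with stated times of 5 min and 15 min, tested at 50 uM; on this read-out higher numbers stand for more inhibition at the one concentration tested (going by the name of the read-out) and lower numbers for less inhibition. Compound 2 `O=C1/C(=C/c2ccccc2)CCC/C1=C\c1ccc(F)c(F)c1` gives 37.8%. Compound 3 `O=C1/C(=C/c2ccccc2)CCC/C1=C\c1ccccc1Br` gives 46.8%; among the three numbers it sits closest to compound 1 and furthest from compound 2, and both gaps lie within the usual scatter. Among the compounds with values here, the one measured step with a single change, a number 1.1 percentage points lower from compound 1 to compound 3 (within the scatter), shows that swapping the substituted ring on this arm left the read-out essentially unchanged.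

Compound 4 `O=C1/C(=C/c2ccccc2)CCC/C1=C\c1cccc(F)c1` differs from compound 3 by 3-fluorophenyl in place of 2-bromophenyl on a double-bonded chain carbon bound to a double-bonded ring carbon. Within the data shown here, no measured step covers exactly this swap; the only comparable step is the one from compound 1 to compound 3, which stayed within the scatter, and compound 2, with a different fluorinated ring at the same place, shows a value also within the scatter of compound 3. A small step, if any, is therefore expected, with a shift of a number 4.8 percentage points lower from compound 3 to compound 4 (within the scatter) anticipated. Compound 4 is estimated to give 42%, within a range of 30% to 54%.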

Compound 4, a percentage reported as inhibition, at one concentration (the size of the read-out at that concentration, not a potency): 39.8%
Beside the measured number, compound 4's estimate is 2.2 percentage points above it, and the stated range covers the measured number.
By their numbers in this assay, from the lowest: compounds 2, 4, 3 and 1 (each within the scatter of the next, the first and the last beyond it).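

With 3-fluorophenyl in place of 2-bromophenyl on a double-bonded chain carbon bound to a double-bonded ring carbon, this assay gives a number 7 percentage points lower from compound 3 to compound 4 (within the scatter), so exchanging both the halogen and its ring position in one step produced no change beyond the scatter. The two further single changes agree: hydrogen in place of fluoro gives a number 2 percentage points higher from compound 2 to compound 4 (within the scatter), and fluoro in place of methyl gives a number 8.1 percentage points lower from compound 1 to compound 4 (within the scatter), so none of the three steps to compound 4 separates these ring substituents. No measurement available here accounts for these numbers.

The compounds shown leave open whether an amine or a carboxylic acid on this ring would give a step beyond the scatter. They also leave open how the two halogens compare at a single ring position, since bromo and fluoro appear here only at different places.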